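This account rests on a few compounds, and the source may have more. Where it says the series, first, only, none or still open, it means among the compounds named here.

Of the compounds shown here, three of a shared core have been measured in an assay on isolated protein for inhibition of Aromatase (Homo sapiens), read by ELISA, using NADPH, with a stated time of 24 h; a higher number here means a weaker inhibitor, a lower number a stronger inhibitor. Compound 1 `Clc1ccc(-c2[nH]c3cc(Cl)ccc3c2Cn2ccnc2)cc1` gives 261 nM. Compound 2 `COc1ccc(-c2[nH]c3cc(Cl)ccc3c2Cn2ccnc2)cc1` gives 277 nM. Compound 3 `Fc1ccc(-c2[nH]c3cc(Cl)ccc3c2Cn2cncn2)cc1` gives 96.9 nM, the lowest number of the three; compound 1 stands nearest to it and compound 2 furthest. The difference between the core of compound 3 and the core of compound 1 is not broken down here.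

One change is seen in two places. From compound 1 to compound 2 the change is methoxy in place of chloro on an aromatic carbon, and it made a 1.1-fold higher number from compound 1 to compound 2 (0.03 log units; within the scatter). Compound 4 `COc1ccc2c(Cn3cncn3)c(-c3ccc(F)cc3)[nH]c2c1` has not yet been measured in this assay. It differs from compound 3 by methoxy in place of chloro on an aromatic carbon. Within the data shown here, this is the same kind of change as the one from compound 1 to compound 2, but not the same: in compound 2 it sits on an aromatic carbon of a six-membered aromatic ring of carbon only, para to a large group, while in compound 4 it sits on a ring that is part of a fused or bridged system of two rings, meta to a fused ring and para to a fused ring.

The expectation for compound 4 rests on the earlier pair, because a 1.1-fold higher number from compound 1 to compound 2 (0.03 log units; within the scatter) lay within the scatter, while the different placing leaves room for a larger step. Compound 4 is expected to give 120 nM, between 50 nM and 300 nM, which would be a 1.2-fold higher number from compound 3 to compound 4 (0.09 log units; within the scatter).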

Compound 4, half-maximal inhibitory concentration: 238 nM
For compound 4 the middle estimate is 2.0-fold (0.30 log units) below the measured one; measured number inside the range.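

In this assay, methoxy in place of chloro on an aromatic carbon of the fused system gave a 2.5-fold higher number from compound 3 to compound 4 (0.39 log units; beyond the scatter), so on the core of compound 3 the swap costs a modest but readable loss of inhibition. Set beside the earlier step on the core of compound 1, which stayed within the scatter, the two steps look different at first sight, yet the gap does not exceed what repeated measurements allow: the same change on two cores in this assay, a 1.1-fold higher number (0.03 log units; within the scatter) from compound 1 to compound 2 and a 2.5-fold higher number (0.39 log units; beyond the scatter) from compound 3 to compound 4, 2.3-fold (0.36 log units) apart, within the scatter of two such steps The pairs therefore do not show that the effect of this change depends on the core, nor do they show that it carries over unaltered; with one pair on each core, and the change sitting in a different place in each pair, the influence of the core cannot be separated from that of the place.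

The compounds shown leave open how an amine or a carboxylic acid on that aromatic carbon of the fused system would read in this assay. They also leave open whether a longer chain such as ethoxy would carry the number further from that of compound 3, or whether a methoxy on the same carbon would give a similar step on the core of compound 1.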